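Solubility notes: 3-fluorobenzyl to (oxan-3-yl)methyl on the core

The source may report more compounds than this note shows. Statements on the series, on what has been measured and on what is new or still open speak of the compounds shown alone.

Compound 1 `CNC(=O)c1cc(C(=O)NC2CC2)cn(Cc2cccc(F)c2)c1=O` carries the shared core with a 3-fluorobenzyl group. In a physicochemical assay for solubility (on this read-out higher numbers stand for higher solubility and lower numbers for lower solubility), compound 1 gives >= 133 ug/mL, which is a limit of the assay and not a number. Compound 2 `CNC(=O)c1cc(C(=O)NC2CCC2)cn(Cc2ccccn2)c1=O` differs from compound 1 at more than one place. In this assay compound 2 gives >= 103 ug/mL, again a limit rather than a number. Within the data shown here, compound 1 thus stands at the limit of >= 133 ug/mL in this assay, at which 1 of the 2 values shown sits, and no step between measured compounds carries a size, so nothing here fixes how large a single change moves this read-out.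

Compound 3 `CNC(=O)c1cc(C(=O)NC2CC2)cn(CC2CCCOC2)c1=O` is the unmeasured analogue; the change from compound 1 is oxan-3-yl in place of 3-fluorophenyl on a saturated chain carbon bound to an aromatic nitrogen. Among the measured compounds shown here, with no measured step to lean on, the expectation is for no change beyond the scatter or a modest rise, the step that the limit leaves unreadable from compound 1 to compound 3 being an estimate only. Compound 3 is estimated at 160 ug/mL, with a range of 60 ug/mL to 400 ug/mL, most likely again reported as a limit.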

Compound 3, solubility: >= 131 ug/mL
Compound 3: only a limit was reported; the forecaster's own chance of this, stated with the estimate: 70%; the middle value lies beyond the limit too.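

Compound 1 and compound 3 are both reported only as limits in this assay, and the step between them cannot be read. The compounds shown leave open the size and direction of any shift in this read-out from 3-fluorobenzyl to (oxan-3-yl)methyl.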